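The source may report more compounds than this note shows. Statements on the series, on what has been measured and on what is new or still open speak of the compounds shown alone.

Measured so far in an ADME assay on RAW264.7 cells (Mus musculus) for cytotoxicity, read by WST assay; on this read-out lower numbers stand for higher toxicity in this test and higher numbers for lower toxicity in this test:
- compound 1 `NC(=O)c1ccc(CN2C(=O)c3ccccc3S2(=O)=O)cc1`: > 100000 nM
- compound 2 `CNC(=O)c1ccc(CN2C(=O)c3ccccc3S2(=O)=O)cc1`: > 100000 nM
- compound 3 `CN(C(=O)OC(C)(C)C)C(=O)c1ccc(CN2C(=O)c3ccccc3S2(=O)=O)cc1`: > 100000 nM

Each of these values is a limit of this assay, not a number. Compound 3 therefore stands only at a limit, and it shares that position with the other two members of the series: the limit of > 100000 nM in this assay, at which 3 of the 3 values shown sit. No ordering among compounds 1, 2 and 3 can be read from this.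

The next compound is compound 4 `CC(C)(C)OC(=O)N(Cc1ccco1)C(=O)c1ccc(CN2C(=O)c3ccccc3S2(=O)=O)cc1`, which differs from compound 3 in one place: furan-2-yl in place of hydrogen on a saturated chain carbon bound to an amide-type nitrogen. The step sits on the methyl that in compound 3 is carried by the amide-type nitrogen, so the nearest measured steps are those that altered substituents on that same nitrogen or its neighbouring carbonyl. All three are unreadable in size: a step that the two limits leave unreadable from compound 1 to compound 2, a step that the two limits leave unreadable from compound 2 to compound 3 and a step that the two limits leave unreadable from compound 1 to compound 3. None of them shows a shift in this assay, and none gives a size that could be carried over.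

The expectation for compound 4 is therefore that this assay again reports no toxicity beyond its limit, with no step beyond the scatter. The estimate implies an expected step that the limit leaves unreadable from compound 3 to compound 4. For compound 4 the estimated value in this assay is 150000 nM (range 60000 nM to 400000 nM).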

Compound 4, concentration lethal to 50% of the cells: > 100000 nM
Compound 4 was reported as a limit; the forecaster's own chance of this, stated with the estimate: 80%; the middle value does not contradict the limit.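

In this assay compound 4 gives > 100000 nM, which is a limit and not a number. No step from compound 3 to compound 4 can be read, and all values remain at one limit: the limit of > 100000 nM in this assay, at which 4 of the 4 values shown sit.

The compounds shown leave open how compounds 1, 2, 3 and 4 rank against one another for toxicity in this test.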